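Compound 2 to compound 4: fluoro in place of chloro

A few compounds are considered here, and "the series" means these few. Any claim that something is new, unique, unknown or untested is made for them only; others in the source may bear on it.

Compound 1 `O=C(NC(=S)Nc1cccc(C(F)(F)F)c1)c1ccccc1` reads > 100000 nM as a limit of the assay and not a number
Compound 2 `FC(F)(F)c1cccc(NC(=S)Nc2ccc(Cl)cc2)c1` reads 11000 nM
Compound 3 `COc1cccc(NC(=S)Nc2cccc(C(F)(F)F)c2)c1` reads 20000 nM

In an ADME assay on Vero 76 cells (Chlorocebus sabaeus) for cytotoxicity, read by crystal violet staining, with a stated time of 96 h (a lower number here means that less compound is tolerated, a higher number that more compound is tolerated), compound 2 stands at 11000 nM and compound 3 stands at 20000 nM within the usual scatter of it, so these two numbers cannot be told apart. Compound 1 offers only a limit and no number to compare.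

Compound 4 `Fc1ccc(NC(=S)Nc2cccc(C(F)(F)F)c2)cc1` has not yet been measured. It differs from compound 2 in one place (fluoro in place of chloro on an aromatic carbon), with fluoro in place of chloro on an aromatic carbon, para to a large group, so that 4-chlorophenyl becomes 4-fluorophenyl. For the measured compounds named here, no two measured compounds differ in a single place, so no measured step speaks directly to this change. Going by the values given here, the only guide is the closeness of compound 3 at 20000 nM to compound 2 at 11000 nM and that closeness gives no reason to expect a large move. The expected change is therefore small, an estimated 1.4-fold higher number from compound 2 to compound 4 (0.13 log units; within the scatter) and nothing beyond the scatter. For compound 4 the estimated value is 15000 nM with an expected range from 6500 nM to 40000 nM in this assay when it is measured.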

Compound 4, half-maximal cytotoxic concentration: 40000 nM
Compound 4: the middle estimate sits 2.7-fold (0.43 log units) below what was measured; the range from low to high includes it.
By their numbers in this assay, from the lowest: compounds 2, 3 and 4 (each within the scatter of the next, the first and the last beyond it). At a limit, above all of these: compound 1.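

In this assay, for the compounds shown here, the exchange of chloro for fluoro on an aromatic carbon, para to a large group, gives the first step in this set that can be read at a single place, a 3.6-fold higher number from compound 2 to compound 4 (0.56 log units; beyond the scatter). Going by these compounds alone, no earlier pair differed in only one place, whereas this pair shows that replacing one heavy atom with another, with no ring, hydrogen-bond donor, hydrogen-bond acceptor or net charge entering or leaving, can move the number beyond the scatter, with more compound tolerated when 4-fluorophenyl replaces 4-chlorophenyl. Compound 1 remains the only compound at a limit of the assay, and that limit is not a number, so it gives no measured distance to the others: the limit of > 100000 nM in this assay, at which 1 of the 4 values shown sits.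

On these data alone, how a bromo, a methyl, a nitrile or an amine at this same place would read in this assay remains open. One pair also leaves open whether the same exchange of chloro for fluoro would give a step of similar size at another place on the ring or on another core.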